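The source may report more compounds than this note shows. Statements on the series, on what has been measured and on what is new or still open speak of the compounds shown alone.

Measured compounds in an assay on HEK-293T cells for inhibition of diacylglycerol lipase-alpha (Homo sapiens), read by colorimetric assay; a higher number here means a weaker inhibitor, a lower number a stronger inhibitor:
Compound 1 `O=C(CCCCCCc1ccccc1)c1ncc(C(=O)C(F)(F)F)o1` gives 1820 nM.
Compound 2 `COc1cnc(C(=O)CCCCCCc2ccccc2)o1` gives > 10000 nM, which is a limit of the assay and not a number.
Compound 3 `O=C(CCCCCCc1ccccc1)c1ncc(-c2ccc(C(=O)C(F)(F)F)cc2)o1` gives > 10000 nM, likewise a limit of the assay.

The one counted step among these, an at least 5.4-fold higher number from compound 1 to compound 2 (0.73 log units; beyond the scatter), is the change (methoxy in place of (trifluoromethyl)carbonyl on an aromatic carbon). Its end point sits at the limit of > 10000 nM in this assay, at which 2 of the 3 values shown sit, so the step is known only as a lower bound. Compound 3 carries the same (trifluoromethyl)carbonyl group on a further ring; the difference between the two cores is not broken down here.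

Compound 4 `COc1ccc(-c2cnc(C(=O)CCCCCCc3ccccc3)o2)cc1` is still to be measured in this assay. It differs from compound 3 by methoxy in place of (trifluoromethyl)carbonyl on an aromatic carbon. This is the same kind of change as that from compound 1 to compound 2, not the same: there the place was on a five-membered aromatic ring with 1 nitrogen and 1 oxygen, next to the ring oxygen; here it is on a six-membered aromatic ring of carbon only, para to a large group. Since compound 3 already sits at the limit > 10000 nM, and the earlier step of an at least 5.4-fold higher number from compound 1 to compound 2 (0.73 log units; beyond the scatter) went toward weaker inhibition, compound 4 is expected to give 30000 nM, between 10000 nM and 150000 nM. The expected step is a step that the limit leaves unreadable from compound 3 to compound 4.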

Compound 4, half-maximal inhibitory concentration: > 10000 nM
Compound 4 gave a limit, no number (the forecaster's own chance of this, stated with the estimate: 90%); the middle value lies beyond the limit too.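

In this assay compound 4 gives > 10000 nM, which is a limit of the assay and not a number. The steps from compound 3 to compound 4 and from compound 2 to compound 4 cannot be read, so methoxy in place of (trifluoromethyl)carbonyl, which on the core of compound 1 gave an at least 5.4-fold higher number from compound 1 to compound 2 (0.73 log units; beyond the scatter), can be neither confirmed nor ruled out on the core of compound 3, because both ends of that step stand at the same limit: the limit of > 10000 nM in this assay, at which 3 of the 4 values shown sit. Among the compounds shown here, the one readable step, an at least 5.4-fold higher number from compound 1 to compound 4 (0.73 log units; beyond the scatter), shows only that 4-methoxyphenyl in place of (trifluoromethyl)carbonyl gives a weaker inhibitor, and it does not tell how large the methoxy change is on the further ring.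

The compounds shown leave open where compound 3 and compound 4 lie beyond the limit, and whether the (trifluoromethyl)carbonyl on the further ring counts at all. They also leave open how a nitrile or a carboxylic acid in that place on the core of compound 1, or a shorter chain, would read in this assay.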